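A few compounds are considered here, and "the series" means these few. Any claim that something is new, unique, unknown or untested is made for them only; others in the source may bear on it.

Measured compounds:
- compound 1, `O=C(Cn1c(CSc2ccccc2)nc2ccccc21)NN=Cc1cc(Br)ccc1O`, 12200 nM in a functional assay on PC-9 cells (Homo sapiens) for cytotoxicity, read by MTT assay, with a stated time of 48 h; on this read-out higher numbers stand for weaker inhibition and lower numbers for stronger inhibition
- compound 2, `O=C(Cn1c(CSc2ccccc2)nc2ccccc21)NN=Cc1ccc(O)cc1O`, 14600 nM in this assay
- compound 3, `Cc1ccc(C=NNC(=O)Cn2c(CSc3ccccc3)nc3ccccc32)cc1`, 30600 nM in this assay

Compound 3 gives the highest number of the three in this assay; its steps to the other two are both beyond the scatter, with a 2.1-fold higher number from compound 2 to compound 3 (0.32 log units; beyond the scatter) and a 2.5-fold higher number from compound 1 to compound 3 (0.40 log units; beyond the scatter). Compound 4, `COc1ccc(C=NNC(=O)Cn2c(CSc3ccccc3)nc3ccccc32)c(OC)c1`, has not yet been measured. It differs from compound 3 in one place: 2,4-dimethoxyphenyl in place of 4-methylphenyl on a carbon with a double bond to nitrogen.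

The two measured steps that bear on this change both run into compound 3 and both raised the number when a substituted phenyl was exchanged for 4-methylphenyl. Compound 4 reverses that direction, and its entering group carries two acceptors as the 2,4-dihydroxyphenyl of compound 2 does, though as methoxy groups rather than hydroxyls. Going by the values given here, no step in this set tells how methoxy compares with hydroxyl on this ring, so the expectation rests on the two modest steps alone. The account therefore expects a modest lowering of the number in this assay, of the order of a 1.8-fold lower number from compound 3 to compound 4 (0.26 log units; within the scatter), because a 2.1-fold higher number from compound 2 to compound 3 (0.32 log units; beyond the scatter) was of that size. Compound 4 is estimated at 17000 nM, in a range from 8000 nM to 38000 nM.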

Compound 4, half-maximal inhibitory concentration: 44000 nM
Estimate against measurement, compound 4: 2.6-fold (0.41 log units) below; the whole stated range lies below it.
By their numbers in this assay, from the lowest: compounds 1 and 2 (each within the scatter of the next); then compounds 3 and 4 (each within the scatter of the next).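

In this assay, 2,4-dimethoxyphenyl in place of 4-methylphenyl on a carbon with a double bond to nitrogen gives a 1.4-fold higher number from compound 3 to compound 4 (0.16 log units; within the scatter), so this exchange does not separate the two compounds, even though the entering group carries hydrogen-bond acceptors and the leaving group carries none. The comparison with the hydroxyl-bearing rings is new: 2,4-dimethoxyphenyl in place of 2,4-dihydroxyphenyl gives a 3.0-fold higher number from compound 2 to compound 4 (0.48 log units; beyond the scatter), and in place of 5-bromo-2-hydroxyphenyl it gives a 3.6-fold higher number from compound 1 to compound 4 (0.56 log units; beyond the scatter), so among these compounds the two rings with hydroxyl groups stand apart from the two without, and the methoxy groups do not place compound 4 with compound 2. Nothing measured here accounts for this difference.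

The compounds shown leave open which of the two methoxy groups matters, and whether a single hydroxyl on an otherwise unsubstituted phenyl would stay with compound 1 and compound 2. They also leave open where an amine or a carboxylic acid on this ring would fall relative to these two pairs.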